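The compounds below may be only part of what the source reports. "The series", "measured", "known", "first", "only" and "open" are said of these compounds alone.

For the measured compounds named here, compound 3 `Cc1ccc(-c2noc(C3CCc4c(nnn4C(C)(C)C)C3)n2)cn1` is one of three compounds measured in a functional assay on U2OS cells for positive allosteric modulation of metabotropic glutamate receptor 5 (Homo sapiens), read by calcium flux, in the presence of a further agent that is not named here; a lower number here means that less compound is needed, a higher number that more compound is needed for the effect. Compound 1 `Fc1ccc(-c2noc(C3CCc4c(nnn4-c4ccc(F)cc4)C3)n2)cc1` gives 15.9 nM, compound 2 `CN1CCC(n2nnc3c2CCC(c2nc(-c4ccc(F)cc4)no2)C3)CC1` gives 3980 nM, and compound 3 gives 1580 nM; compound 3 thus stands second highest, nearer to compound 2 than to compound 1. Compound 4 `CC(C)Cc1noc(C2CCc3c(nnn3C(C)(C)C)C2)n1` differs from compound 3 in one place: isobutyl in place of 6-methylpyridin-3-yl on an aromatic carbon. Going by the values given here, the only measured step, a 250-fold higher number from compound 1 to compound 2 (2.40 log units; beyond the scatter), concerns a different place on the shared core, so no measured step bears directly on this change. With nothing to go on, a moderately higher number is estimated, as the step of a 3.2-fold higher number from compound 3 to compound 4 (0.50 log units; beyond the scatter). For compound 4 the expected value in this assay is 5000 nM, with a range from 1000 nM to 25000 nM.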

Compound 4, half-maximal effective concentration: 1000 nM
Compound 4: middle estimate off by 5.0-fold (0.70 log units), on the high side; the range from low to high includes it.
By their numbers in this assay, from the lowest: compound 1; then compounds 4 and 3 (each within the scatter of the next); then compound 2.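

Putting isobutyl in place of 6-methylpyridin-3-yl gives a 1.6-fold lower number from compound 3 to compound 4 (0.20 log units; within the scatter). On this aromatic carbon, then, a chain of 4 heavy atoms with no ring and a six-membered aromatic ring of 7 heavy atoms with a hydrogen-bond acceptor cannot be told apart in this pair, so neither the ring nor the acceptor is shown to matter here. Nothing available explains why the two groups read alike.

From the compounds shown here alone, whether an amine or a carboxylic acid on this carbon would also read alike remains open. So does whether the same swap would leave the number unchanged with 4-fluorophenyl on the aromatic nitrogen, as in compound 1.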